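Ester chain length and plasma stability in one biaryl series

The source may report more compounds than this note shows. Statements on the series, on what has been measured and on what is new or still open speak of the compounds shown alone.

Measured so far in an ADME assay on a cell-free system (plasma, Homo sapiens) for metabolic stability, read by LC-MS; a lower number here means that the compound disappears faster, a higher number that the compound lasts longer:
compound 1 `CCCCOC(=O)c1cccc(-c2cc(C(=O)Nc3ccncc3)ccc2CN)c1` gives 0.367 h
compound 2 `CCCCCCOC(=O)c1cccc(-c2cc(C(=O)Nc3ccncc3)ccc2CN)c1` gives 0.833 h
compound 3 `CCCOC(=O)c1cccc(-c2cc(C(=O)Nc3ccncc3F)ccc2CN)c1` gives 0.317 h

For the measured compounds named here, compound 2 and compound 1 share one core and differ only in the ester chain; the step of a 2.3-fold lower number from compound 2 to compound 1 (0.36 log units; beyond the scatter) is the one counted change here, (hydrogen in place of ethyl on a saturated chain carbon, four bonds along the chain from an oxygen next to a carbonyl group). Compound 3 carries a second core; how it differs from compound 2 is not broken down here. Compound 3 and compound 1 lie within the scatter of each other in this assay, so no order between them is claimed.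

Compound 4 `COC(=O)c1cccc(-c2cc(C(=O)Nc3ccncc3F)ccc2CN)c1` is not yet measured. It differs from compound 3 by hydrogen in place of ethyl on a saturated chain carbon bound to an oxygen next to a carbonyl group. This is the same kind of change as from compound 2 to compound 1, but not the same: there the hydrogen replaced ethyl on a saturated chain carbon four bonds along the chain from an oxygen next to a carbonyl group, here on a saturated chain carbon bound to an oxygen next to a carbonyl group. Going by the values given here, with only one measured example of shortening the chain, the expectation rests on compound 2 and compound 1, whose step a 2.3-fold lower number from compound 2 to compound 1 (0.36 log units; beyond the scatter) went toward faster disappearance, and on compound 3 already standing at 0.317 h. The half-life of compound 4 is expected to fall by about a 2.1-fold lower number from compound 3 to compound 4 (0.32 log units; beyond the scatter), a step of similar size to the earlier one. Compound 4 is therefore estimated at 0.15 h, most likely between 0.07 h and 0.35 h.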

Compound 4, half-life: 1.08 h
Compound 4: middle estimate off by 7.2-fold (0.86 log units), on the low side; measured number above the stated range.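

In this assay, replacing ethyl with hydrogen on a saturated chain carbon bound to an oxygen next to a carbonyl group gives a 3.4-fold higher number from compound 3 to compound 4 (0.53 log units; beyond the scatter), so the methoxycarbonyl compound lasts longer than its propoxycarbonyl partner. Set beside the earlier step, this change of the same kind runs in the opposite direction, and the two steps differ: the same change on two cores in this assay, a 2.3-fold lower number (0.36 log units; beyond the scatter) from compound 2 to compound 1 and a 3.4-fold higher number (0.53 log units; beyond the scatter) from compound 3 to compound 4, 7.7-fold (0.89 log units) apart, beyond the scatter of two such steps. A shorter ester chain therefore cannot be assumed to give the same direction of change on both cores, but this does not show that the core decides the outcome, as the two steps also sit at different places on the chain, four bonds along from the oxygen in one and on the carbon bound to it in the other, and core and place cannot be separated with one pair per core.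

Open, as far as these compounds go, is how propoxycarbonyl and methoxycarbonyl behave on the core of compound 1, and how the butyl and hexyl esters behave on the core of compound 3, which would separate the core from the place of the change. Also open, from the compounds shown here alone, is whether a carboxylic acid, an amide in place of the ester or a branched chain follows either step.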